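This account rests on a few compounds, and the source may have more. Where it says the series, first, only, none or still open, it means among the compounds named here.

Compound 3 `Nc1sc(-c2ccc([N+](=O)[O-])cc2)c(-c2ccc(Cl)cc2)c1C(=O)NC1CCCCC1` gives 25900 nM in a functional assay on PC-3 cells (Homo sapiens) for cytotoxicity, read by sulforhodamine B assay, with a stated time of 72 h (on this read-out lower numbers stand for stronger inhibition and higher numbers for weaker inhibition), the highest of the two numbers reported here. Compound 1 `Nc1sc(-c2ccc(Cl)cc2)c(-c2ccc(Cl)cc2)c1C(=O)N1CCCC1` gives 6220 nM in this assay, a lower number, and the gap between the two lies beyond the usual scatter. For compound 2 `Nc1sc(-c2ccc([N+](=O)[O-])cc2)c(-c2ccc(Cl)cc2)c1C(=O)NC1CC1` the read-out in this assay stands as "not determined" (no result reported). Compound 4 `Nc1sc(-c2ccc([N+](=O)[O-])cc2)c(-c2ccc(Cl)cc2)c1C(=O)N1CCCC1` has not been measured; it differs from compound 3 in one place, (pyrrolidin-1-yl in place of cyclohexylamino on a carbonyl carbon). For the measured compounds named here, no step between two measured compounds isolates this change, since compound 1 also carries a different aryl group. Because compound 1 gives 6220 nM with the same pyrrolidinyl amide, the step of a 3.2-fold lower number from compound 3 to compound 4 (0.51 log units; beyond the scatter) is expected to run toward a lower number, beyond the scatter. Compound 4 is estimated at 8000 nM, within 3000 nM to 30000 nM.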

Compound 4, half-maximal inhibitory concentration: 42600 nM
For compound 4 the middle estimate is 5.3-fold (0.73 log units) below the measured one; the measured number lies above the stated range.
By their numbers in this assay, from the lowest: compound 1; then compounds 3 and 4 (each within the scatter of the next).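

In this assay, pyrrolidin-1-yl in place of cyclohexylamino on the carbonyl carbon gives a 1.6-fold higher number from compound 3 to compound 4 (0.22 log units; within the scatter) and so does not separate the two amides on this core, even though the amide hydrogen is lost. The aryl group does separate compounds, as nitro in place of chloro on an aromatic carbon gives a 6.8-fold higher number from compound 1 to compound 4 (0.84 log units; beyond the scatter) with the pyrrolidin-1-yl amide held constant. No evidence available here accounts for either result.

The compounds shown leave open whether the amide change would read the same with chloro on the aromatic carbon. They also leave open how an amine or a carboxylic acid in place of nitro would read.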